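Compound 3 to compound 4: cytotoxicity working notes

The compounds below may be only part of what the source reports. "The series", "measured", "known", "first", "only" and "open" are said of these compounds alone.

Measured in an ADME assay on MDBK cells (Bos taurus) for cytotoxicity (a higher number here means that more compound is tolerated, a lower number that less compound is tolerated), as half-maximal cytotoxic concentration:
- compound 1 `Clc1ccccc1Cn1ccc2nc(-c3ccccc3)nc-2c1`: > 100000 nM
- compound 2 `N#Cc1ccc(Cn2ccc3nc(-c4ccccc4)nc-3c2)cc1`: > 100000 nM
- compound 3 `c1ccc(-c2nc3cc[nH]cc-3n2)cc1`: > 100000 nM

Compound 3 stands at > 100000 nM, which is a limit and not a number. Compound 4 `CC(C)=CCn1ccc2nc(-c3ccccc3)nc-2c1` differs from it by one change: 3-methylbut-2-en-1-yl in place of hydrogen on an aromatic nitrogen. Within the data shown here, the one measured step, a step that the two limits leave unreadable from compound 1 to compound 2, has no size to carry over. Compound 1 also bears a substituent on an aromatic nitrogen, and its > 100000 nM is a limit. Compound 2 does too, and its > 100000 nM is likewise a limit. Among the measured compounds shown here, the only guide is the limit of > 100000 nM in this assay, at which 3 of the 3 values shown sit. No step beyond the scatter is therefore expected in this assay, and another limit is the likeliest report. The expected step is a number no higher from compound 3 to compound 4 (the limit leaves the size open). The estimate for compound 4 is 100000 nM, with an expected range of 40000 nM to 100000 nM.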

Compound 4, half-maximal cytotoxic concentration: > 100000 nM
Compound 4: a limit, no number (the forecaster's own chance of this, stated with the estimate: 75%); the middle value lies on the limit itself.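

No new step can be read between compound 4 and compound 1, compound 2 or compound 3 in this assay, since each result is a limit: the limit of > 100000 nM in this assay, at which 4 of the 4 values shown sit.

The compounds shown leave open at what concentration any of them becomes cytotoxic, and whether the substituent on the aromatic nitrogen changes that concentration.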